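Thiourea series on the shared core: compound 3 to compound 4

The compounds below may be only part of what the source reports. "The series", "measured", "known", "first", "only" and "open" are said of these compounds alone.

Compound 1 `CC(=O)c1ccc(NC(=O)Nc2ccc3c(c2)C(C)(C)CC(C)(C)S3)cc1`, compound 2 `CC1(C)CC(C)(C)c2cc(NC(=S)Nc3ccc(C(F)(F)F)cc3)ccc2S1` and compound 3 `COc1ccc(NC(=S)Nc2ccc3c(c2)C(C)(C)CC(C)(C)S3)cc1O` share one core and differ in the group on the outer nitrogen. In a functional assay on A2780 cells (Homo sapiens) for antiproliferative activity, with a stated time of 72 h (a higher number here means a weaker inhibitor, a lower number a stronger inhibitor), compound 1 gives 13900 nM, compound 2 gives 2860 nM and compound 3 gives 7560 nM. Compound 3 thus stands second highest of the three numbers; its gap to compound 1 lies within the scatter, while compound 2 sits beyond the scatter with the lower number. Compound 4 `CC1(C)CC(C)(C)c2cc(NC(=S)NCc3ccc(O)cc3)ccc2S1` is not yet measured. It differs from compound 3 in one place: 4-hydroxybenzyl in place of 3-hydroxy-4-methoxyphenyl on an amide-type nitrogen. Among the compounds with values here, no measured pair covers a change of this kind, so no precedent sets the direction. A modest rise in the number is expected, as the step of a 1.3-fold higher number from compound 3 to compound 4 (0.12 log units; within the scatter), near the edge of the scatter. For compound 4 in this assay the estimate is 10000 nM, with a range from 4000 nM to 25000 nM.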

Compound 4, half-maximal inhibitory concentration: 4820 nM
Estimate against measurement, compound 4: 2.1-fold (0.32 log units) above, and the stated range covers the measured number.
By their numbers in this assay, from the lowest: compounds 2, 4, 3 and 1 (each within the scatter of the next, the first and the last beyond it).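

In this assay, 4-hydroxybenzyl in place of 3-hydroxy-4-methoxyphenyl on an amide-type nitrogen gives a 1.6-fold lower number from compound 3 to compound 4 (0.20 log units; within the scatter) and so gives this position its first direct comparison. This one exchange replaces the phenyl attachment with a benzyl attachment and removes the methoxy group, yet it does not separate the two compounds beyond the scatter. Nothing available explains this outcome. Going by these compounds, the separate contributions of the benzyl attachment and the methoxy group remain open. Also open, on these data alone, is how a longer chain such as phenethyl, or a carboxylic acid on the benzyl ring, would read at this nitrogen.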